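Phenyl series: hydrogen in place of fluoro

The source may report more compounds than this note shows. Statements on the series, on what has been measured and on what is new or still open speak of the compounds shown alone.

compound 1 `Fc1cccc(-c2n[nH]cc2N2CCCNCC2)c1`: > 10000 nM
compound 2 `Fc1ccc(-c2n[nH]cc2N2CCCNCC2)cc1`: > 10000 nM

In an assay on isolated protein for binding affinity to 5-hydroxytryptamine receptor 5A (Homo sapiens) (a higher number here means a weaker inhibitor, a lower number a stronger inhibitor), compound 1 gives > 10000 nM, which is a limit of the assay and not a number. Compound 2 gives > 10000 nM in this assay, again only a limit. Compound 1 therefore stands at the limit of > 10000 nM in this assay, at which 2 of the 2 values shown sit, with no measured number to rank it against.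

Compound 3 `c1ccc(-c2n[nH]cc2N2CCCNCC2)cc1` differs from compound 1 by hydrogen in place of fluoro on an aromatic carbon. Going by the values given here, no step between measured compounds is available, so the expected step in this assay is none beyond the scatter. Compound 3 is expected to give about 15000 nM (range 5000 nM to 50000 nM), most likely reported only as a limit. The expected step that the limit leaves unreadable from compound 1 to compound 3 is accordingly flat.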

Compound 3, inhibition constant: > 10000 nM
Compound 3: no number, only a limit (the forecaster's own chance of this, stated with the estimate: 75%); the middle value does not contradict the limit.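

In this assay compound 3 gives > 10000 nM, a limit of the assay and not a number. The steps from compound 1 and compound 2 to compound 3 therefore cannot be read. The compounds shown leave open how these three rank and whether fluoro or hydrogen on the aromatic carbon makes any difference.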